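The source may hold more compounds than are shown below. What is called first, only, known or untested is meant among the compounds shown, and "the series" means these compounds.

For the measured compounds named here, in an ADME assay on Vero cells (Chlorocebus sabaeus) for inhibition, read by sulforhodamine B assay, with a stated time of 48 h (on this read-out higher numbers stand for weaker inhibition of growth and lower numbers for stronger inhibition of growth), compound 3 `COc1ccc(/C=N/NC(=S)NC(C)(C)[C@H]2CC=C(C)CC2)cc1` gives 70100 nM, the only actual number among the three values recorded so far. Compound 1 `CC1=CC[C@H](C(C)(C)N=C=S)CC1` gives > 100000 nM, which is a limit of the assay and not a number. Compound 2 `CC1=CC[C@H](C(C)(C)NC(=S)NN)CC1` gives > 100000 nM, again a limit. Going by the values given here, the one step between measured compounds, a step that the two limits leave unreadable from compound 1 to compound 2, cannot be sized because the limit of > 100000 nM in this assay, at which 2 of the 3 values shown sit, caps both of its ends; it sits on a saturated chain carbon and not on the aromatic ring. Compound 4 `CC1=CC[C@H](C(C)(C)NC(=S)N/N=C/c2ccc(F)cc2)CC1` still awaits measurement in this assay; it differs from compound 3 by fluoro in place of methoxy on an aromatic carbon. Among the compounds with values here, no measured step touches a substituent on the six-membered aromatic ring of carbon only, so nothing recorded bears directly on this change, and the step is expected to stay within the usual scatter of this assay; the estimated step is a 1.0-fold lower number from compound 3 to compound 4 (0.00 log units; within the scatter). Compound 4 is therefore expected at 70000 nM, within 35000 nM to 140000 nM, with a real chance that only the limit is reported.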

Compound 4, concentration for total growth inhibition: > 100000 nM
Compound 4: a limit, no number; the forecaster's own chance of this, stated with the estimate: 35%; middle value at least 1.4-fold (0.15 log units) from the limit.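

Fluoro in place of methoxy on an aromatic carbon, para to a large group, is the only measured change on the aromatic ring, and in this assay it gives an at least 1.4-fold higher number from compound 3 to compound 4 (0.15 log units; that floor lies within the scatter), so this position now has a reading, though only a floor that does not separate the two compounds. Compound 4 gives > 100000 nM, which is a limit of the assay and not a number. The true size of this step stays unknown, and compound 3 remains the only compound with a number, because of where the values fall: the limit of > 100000 nM in this assay, at which 3 of the 4 values shown sit.

The compounds shown leave open what an amine, a carboxylic acid or an ethoxy group would give on this aromatic carbon. Also open, from the compounds shown here alone, is whether any group at this position can move the number clearly beyond the scatter.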